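Pyridinyl for aryl on the triazole: compound 3 to compound 4

The source may report more compounds than this note shows. Statements on the series, on what has been measured and on what is new or still open speak of the compounds shown alone.

Measured compounds:
compound 1 `CC(C)=CCC/C(C)=C/CC/C(C)=C/CC[C@@H]1[C@@]2(C)CC/C(=N\OCc3cn(-c4ccc(F)c(Cl)c4)nn3)C(C)(C)[C@@H]2CC[C@@]1(C)O`, 26900 nM
compound 2 `CC(C)=CCC/C(C)=C/CC/C(C)=C/CC[C@@H]1[C@@]2(C)CC/C(=N\OCc3cn(-c4ccncc4)nn3)C(C)(C)[C@@H]2CC[C@@]1(C)O`, 17400 nM
compound 3 `CC(C)=CCC/C(C)=C/CC/C(C)=C/CC[C@@H]1[C@@]2(C)C/C(=C\c3ccc(OCc4cn(-c5ccccc5)nn4)cc3)C(=O)C(C)(C)[C@@H]2CC[C@@]1(C)O`, 21000 nM

Against a functional assay on DU-145 cells (Homo sapiens) for cytotoxicity, read by MTT assay, with a stated time of 48 h (a lower number here means a stronger inhibitor, a higher number a weaker inhibitor), compound 3 stands second highest of the three numbers; its nearest neighbour is compound 2, whose value is within the scatter of it, and compound 1 is the furthest, also within the scatter. All three numbers therefore sit close together.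

Compound 4 `CC(C)=CCC/C(C)=C/CC/C(C)=C/CC[C@@H]1[C@@]2(C)C/C(=C\c3ccc(OCc4cn(-c5ccncc5)nn4)cc3)C(=O)C(C)(C)[C@@H]2CC[C@@]1(C)O` differs from compound 3 by pyridin-4-yl in place of phenyl on an aromatic nitrogen. Going by the values given here, the one measured step that bears on this change is the step from compound 1 to compound 2, which carries the same replacement on the same kind of aromatic nitrogen, though on a different part of the shared core: a 1.5-fold lower number from compound 1 to compound 2 (0.19 log units; within the scatter). That step did not leave the scatter, so no change beyond the scatter is expected here either, with at most a slight lean toward a lower number in this assay. Compound 4 is therefore expected to give 17000 nM, in the range 8000 nM to 40000 nM, which means an expected step of a 1.2-fold lower number from compound 3 to compound 4 (0.09 log units; within the scatter).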

Compound 4, half-maximal inhibitory concentration: 25700 nM
Compound 4: the middle estimate sits 1.5-fold (0.18 log units) below what was measured; measured number inside the range.
By their numbers in this assay, from the lowest: compounds 2, 3, 4 and 1 (each within the scatter of the next).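

Pyridin-4-yl in place of phenyl, on an aromatic nitrogen of the five-membered aromatic ring with 3 nitrogen, gives no readable change in this assay on this second attachment to the shared core: a 1.2-fold higher number from compound 3 to compound 4 (0.09 log units; within the scatter). With a 1.5-fold lower number from compound 1 to compound 2 (0.19 log units; within the scatter), where 3-chloro-4-fluorophenyl was the group leaving, there are now two pyridin-4-yl replacements on two different attachments, and neither step leaves the scatter in this assay. No measurement is available that could explain why the numbers stay so close together.

Still open, from the compounds shown here alone, is whether any group on this aromatic nitrogen can move the number beyond the scatter, for example a phenyl ring bearing an amine or a carboxylic acid. Also open, going by these compounds, is whether pyridin-3-yl would read the same as pyridin-4-yl.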